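Dichlorophenyl urea in place of the nitrophenyl thiourea

The source may hold more compounds than are shown below. What is called first, only, known or untested is meant among the compounds shown, and "the series" means these compounds.

Compound 1 `O=C(NCCNS(=O)(=O)c1ccc(-c2ccccc2Oc2ccc(O)c(O)c2)s1)Nc1cc(Cl)cc(Cl)c1`: > 20000 nM (a limit)
Compound 2 `COc1cccc(NC(=O)NCCNS(=O)(=O)c2ccc(-c3ccccc3OCc3ccccc3)s2)c1`: > 50000 nM (a limit)
Compound 3 `O=[N+]([O-])c1cccc(NC(=S)NCCNS(=O)(=O)c2ccc(-c3ccccc3OCc3ccccc3)s2)c1`: 12800 nM

For the measured compounds named here, in a functional assay on HeLa cells (Homo sapiens) for inhibition, read by CCK-8 assay, with a stated time of 48 h (a lower number here means a stronger inhibitor, a higher number a weaker inhibitor), compound 3 gives 12800 nM, the only actual number so far. Compound 1 and compound 2 are known only as limits, shown in the list.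

Compound 4 `O=C(NCCNS(=O)(=O)c1ccc(-c2ccccc2OCc2ccccc2)s1)Nc1cc(Cl)cc(Cl)c1` differs from compound 3 in one place, on an amine nitrogen whose other neighbours are saturated chain carbon: a group of 11 heavy atoms (7 carbon, 1 nitrogen, 1 oxygen, 2 chlorine; one six-membered aromatic ring of carbon only) in place of a group of 12 heavy atoms (7 carbon, 2 nitrogen, 2 oxygen, 1 sulfur; one six-membered aromatic ring of carbon only), on an amine nitrogen. The group that enters is (3,5-dichlorophenyl)carbamoyl.

Going by the values given here, one measured step bears on this change: an at least 3.9-fold lower number from compound 2 to compound 3 (0.59 log units; beyond the scatter), which lies beyond the scatter. Its size is only a bound, since one end of it is a limit. Compound 4, like compound 2, carries a carbamoyl group in this place, so part of that step is expected to be given back. Compound 1 carries the same (3,5-dichlorophenyl)carbamoyl with a different remainder and reports only the limit > 20000 nM. A modest move towards a higher number in this assay is therefore expected, and a limit instead of a number would be no surprise. The expected step is a 2.0-fold higher number from compound 3 to compound 4 (0.29 log units; within the scatter). For compound 4 the estimated value is 25000 nM, with an expected range of 9000 nM to 60000 nM.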

Compound 4, half-maximal inhibitory concentration: > 20000 nM
Compound 4 ended at the assay's limit; the forecaster's own chance of this, stated with the estimate: 45%; the middle value is on the limit's open side.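

On these data alone, on the amine nitrogen, (3,5-dichlorophenyl)carbamoyl in place of the nitrophenyl thiourea group gives an at least 1.5-fold higher number from compound 3 to compound 4 (0.19 log units; that floor lies within the scatter) in this assay, so the printed size is a floor and the true size of the change stays unknown. The steps linking compound 4 to compound 1 and to compound 2 cannot be read, since both ends of each are limits. Compound 4 gives > 20000 nM, a limit of the assay and not a number, and with it compound 3 remains the only compound in the series with an actual value: the limit of > 20000 nM in this assay, at which 2 of the 4 values shown sit.

The replacement changes the thiocarbonyl and the ring substituents at once, so a nitrophenyl urea and a dichlorophenyl thiourea would be needed to tell which of the two changes goes with the value of compound 3. Also open is whether an amine or a carboxylic acid in place of the benzyl on the oxygen would bring any of these compounds to a measurable value in this assay.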